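Moving a chlorine on the pendant ring of compound 1

A few compounds are considered here, and "the series" means these few. Any claim that something is new, unique, unknown or untested is made for them only; others in the source may bear on it.

Among the measured compounds shown here, compound 1 `O=C1/C(=C\c2ccc(O)cc2)c2ccccc2N1c1c(Cl)cccc1Cl` is the one member of this small set with a measured number. In a functional assay on L132 cells (Homo sapiens) for cytotoxicity, read by MTT assay, with a stated time of 72 h (on this read-out lower numbers stand for an effect already at smaller amounts and higher numbers for an effect only at larger amounts of compound), compound 1 gives 30 ug/mL. Compound 2 `CN(C)c1ccc(/C=C2\C(=O)N(c3c(Cl)cccc3Cl)c3ccccc32)cc1` reaches only a limit of the assay, > 100 ug/mL. Compound 3 `O=C1/C(=C\c2ccccc2Cl)c2ccccc2N1c1c(Cl)cccc1Cl` likewise stops at a limit, > 100 ug/mL. Both partners of compound 1 therefore sit at the limit of > 100 ug/mL in this assay, at which 2 of the 3 values shown sit.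

Compound 4 `O=C1/C(=C\c2cccc(Cl)c2)c2ccccc2N1c1c(Cl)cccc1Cl` differs from compound 1 by 3-chlorophenyl in place of 4-hydroxyphenyl on a double-bonded chain carbon bound to a double-bonded ring carbon. For the measured compounds named here, two measured steps bear on this change. The step of an at least 3.3-fold higher number from compound 1 to compound 2 (0.52 log units; beyond the scatter) swaps the hydroxy for another group, and the step of an at least 3.3-fold higher number from compound 1 to compound 3 (0.52 log units; beyond the scatter) swaps the whole 4-hydroxyphenyl for a chlorophenyl, as the change to compound 4 does. Both moves away from the 4-hydroxyphenyl pushed the number to a limit. The expectation for compound 4 is thus a clearly higher number, shown as a 3.3-fold higher number from compound 1 to compound 4 (0.52 log units; beyond the scatter), with a real chance of only a limit. The estimated value for compound 4 is 100 ug/mL, in the range from 40 ug/mL to 300 ug/mL.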

Compound 4, concentration for half-maximal effect: 16 ug/mL
The estimate for compound 4 lay 6.3-fold (0.80 log units) above the measured number, and the stated range ends above it.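

In this assay the 4-hydroxyphenyl turns out not to be required at this place on a double-bonded chain carbon, since 3-chlorophenyl, with 0 hydrogen-bond donors and 0 hydrogen-bond acceptors, stands level with it (a 1.9-fold lower number from compound 1 to compound 4 (0.27 log units; within the scatter)). Where the chlorine sits on the pendant ring matters, as the two chlorophenyl isomers part clearly (an at least 6.2-fold lower number from compound 3 to compound 4 (0.79 log units; beyond the scatter)). The gap to the 4-(dimethylamino)phenyl is also clear (an at least 6.2-fold lower number from compound 2 to compound 4 (0.79 log units; beyond the scatter)), and both of these steps are minimum sizes because compound 2 and compound 3 each rest at a limit: (the limit of > 100 ug/mL in this assay, at which 2 of the 4 values shown sit).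

On these data alone, whether this level of effect belongs to chlorine itself or would hold for other groups stays open, and a 3-bromophenyl or a 3-aminophenyl would help to separate the two. As far as these compounds go, the true positions of compound 2 and compound 3 also remain unknown.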